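Ribose on the Ring Nitrogen: Expected Cytotoxicity

A few compounds are considered here, and "the series" means these few. Any claim that something is new, unique, unknown or untested is made for them only; others in the source may bear on it.

Three small compounds share a core that carries a triple bond. Compound 1 `CCCCC#Cc1c[nH]c(=O)[nH]c1=O` bears a butyl chain on the triple bond, compound 2 `C[Si](C)(C)C#Cc1c[nH]c(=O)[nH]c1=O` bears a trimethylsilyl group there, and compound 3 `O=c1[nH]cc(C#CC(O)c2ccccc2)c(=O)[nH]1` bears a hydroxy(phenyl)methyl group. In an ADME assay on Vero cells (Chlorocebus sabaeus) for cytotoxicity, read by MTT assay (on this read-out higher numbers stand for lower toxicity in this test and lower numbers for higher toxicity in this test), compound 1 gives 253000 nM, compound 2 gives 270000 nM, and compound 3 gives 242000 nM. Going by the values given here, the one measured step, a 1.1-fold higher number from compound 1 to compound 2 (0.03 log units; within the scatter), shows that swapping groups on the triple bond left the read-out unchanged beyond the scatter, and compound 3 sits within the scatter of both others, so all three look alike in this test.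

Compound 4 `O=c1[nH]c(=O)n([C@@H]2O[C@H](CO)[C@@H](O)[C@H]2O)cc1C#CC(O)c1ccccc1` differs from compound 3 by 3,4-dihydroxy-5-(hydroxymethyl)oxolan-2-yl in place of hydrogen on an aromatic nitrogen. No measured step touches this position, and the only step shown concerns the triple-bonded carbon. Given that all three numbers so far cluster together, compound 4 is expected to stay close to them, with a step of a 1.1-fold lower number from compound 3 to compound 4 (0.04 log units; within the scatter) that is not expected to exceed the scatter. Compound 4 is thus estimated at 220000 nM, with a range from 80000 nM to 450000 nM.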

Compound 4, half-maximal cytotoxic concentration: 65400 nM
For compound 4 the middle estimate is 3.4-fold (0.53 log units) above the measured one; measured number below the stated range.
By their numbers in this assay, from the lowest: compound 4; then compounds 3, 1 and 2 (each within the scatter of the next).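

Going by these compounds alone, putting 3,4-dihydroxy-5-(hydroxymethyl)oxolan-2-yl in place of hydrogen on the aromatic nitrogen gives in this assay a 3.7-fold lower number from compound 3 to compound 4 (0.57 log units; beyond the scatter) and so moves the number beyond the scatter, which the one measured change on the triple-bonded carbon did not do. This nitrogen is therefore a place where a change can shift the read-out, here modestly and in the direction of higher toxicity in this test. No supporting measurement bears on what lies behind this shift.

The compounds shown leave open whether a simple methyl or a short open chain such as 2-hydroxyethyl on this nitrogen would shift the number too. They also leave open whether the same oxolanyl group would act alike with the butyl chain of compound 1 or the trimethylsilyl group of compound 2.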